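Taking the methyl off compound 2

The source may hold more compounds than are shown below. What is called first, only, known or untested is meant among the compounds shown, and "the series" means these compounds.

Measured in a functional assay on HCT-116 cells (Homo sapiens) for antiproliferative activity, read by MTT assay, with a stated time of 72 h; on this read-out higher numbers stand for weaker inhibition and lower numbers for stronger inhibition:
compound 1 `COc1ccc(/C=C2\S/C(=N\c3ccc(F)cc3)N(C)C2=O)cc1`: 13300 nM
compound 2 `COc1ccc(/C=C2\S/C(=N\c3ccc(C)cc3)N(C)C2=O)cc1`: > 100000 nM (a limit of the assay)

On these numbers, compound 2 gives > 100000 nM, which is a limit and not a number. Compound 3 `COc1ccc(/C=C2\S/C(=N\c3ccccc3)N(C)C2=O)cc1` has hydrogen in place of methyl on an aromatic carbon. Among the measured compounds shown here, only one measured step bears on this change: an at least 7.5-fold higher number from compound 1 to compound 2 (0.87 log units; beyond the scatter). On that evidence, a step of similar size toward lower numbers is expected in this assay. The expected step is an at least 3.3-fold lower number from compound 2 to compound 3 (0.52 log units; beyond the scatter). For compound 3 the estimated value is 30000 nM, with an expected range of 9000 nM to 100000 nM.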

Compound 3, half-maximal inhibitory concentration: > 100000 nM
Compound 3 was reported as a limit; the forecaster's own chance of this, stated with the estimate: 25%; middle value at least 3.3-fold (0.52 log units) from the limit.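

Removing the methyl did not lift the compound off the limit: in this assay compound 3 gives > 100000 nM, which is a limit of the assay. Replacing fluoro with hydrogen gives an at least 7.5-fold higher number from compound 1 to compound 3 (0.87 log units; beyond the scatter), so among the groups shown at this position, only the fluoro of compound 1 gives a readable value. The step between the other two compounds cannot be read, since both stand at the same limit: the limit of > 100000 nM in this assay, at which 2 of the 3 values shown sit.

As far as these compounds go, whether chloro, an amine or a carboxylic acid at this position would give a readable value remains open. So does any order between hydrogen and methyl.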